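Bis-indolyl methanes bearing nitro and nitrile groups

This account rests on a few compounds, and the source may have more. Where it says the series, first, only, none or still open, it means among the compounds named here.

Measured compounds:
Compound 1 `O=[N+]([O-])c1ccc2[nH]cc(C(c3ccc(Br)cc3)c3c[nH]c4ccc([N+](=O)[O-])cc34)c2c1` gives > 100000 nM in a functional assay on HeLa cells (Homo sapiens) for inhibition, read by MTT assay, with a stated time of 48 h (on this read-out lower numbers stand for stronger inhibition and higher numbers for weaker inhibition), a limit of the assay rather than a number.
Compound 2 `O=[N+]([O-])c1ccc(C(c2c[nH]c3ccc([N+](=O)[O-])cc23)c2c[nH]c3ccc([N+](=O)[O-])cc23)cc1` gives > 100000 nM in this assay, again a limit and not a number.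
Compound 3 `N#Cc1ccc2[nH]cc(C(c3ccc(Br)cc3)c3c[nH]c4ccc(C#N)cc34)c2c1` gives > 100000 nM in this assay, also a limit and not a number.

The change from compound 1 to compound 2 is nitro in place of bromo on an aromatic carbon. In this assay it made a step that the two limits leave unreadable from compound 1 to compound 2, which rests on (the limit of > 100000 nM in this assay, at which 3 of the 3 values shown sit). The difference between the core of compound 1 and the core of compound 3 is not broken down here.

Compound 4 `N#Cc1ccc2[nH]cc(C(c3ccc([N+](=O)[O-])cc3)c3c[nH]c4ccc(C#N)cc34)c2c1` has not yet been measured in this assay. For the measured compounds named here, it differs from compound 3 by nitro in place of bromo on an aromatic carbon, the same change as the one from compound 1 to compound 2, at the same place in both pairs.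

For compound 4 the step expected in this assay is a number no higher from compound 3 to compound 4 (the limit leaves the size open). This expectation rests on compound 3, which gives > 100000 nM in this assay. It rests further on a step that the two limits leave unreadable from compound 1 to compound 2, together with the limit of > 100000 nM in this assay, at which 3 of the 3 values shown sit. Compound 4 is therefore estimated at 100000 nM in this assay, with an expected range from 30000 nM to 300000 nM, and it is expected that the assay will most likely again report only a limit rather than a number.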

Compound 4, half-maximal inhibitory concentration: > 100000 nM
Compound 4: a limit, no number; the forecaster's own chance of this, stated with the estimate: 85%; the middle value lies on the limit itself.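

In this assay compound 4 gives > 100000 nM, a limit and not a number. No step can be read from compound 3 to compound 4, as with the other pairs in the series: the limit of > 100000 nM in this assay, at which 4 of the 4 values shown sit.

The compounds shown leave open what size of effect, if any, nitro in place of bromo has in this assay, and whether any change to the shared core would yield a number.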